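Fluoro to Chloro: Expected Intrinsic Activity of Compound 4

This account rests on a few compounds, and the source may have more. Where it says the series, first, only, none or still open, it means among the compounds named here.

Compound 1, `COc1cc2c(cc1N1C[C@@H](C)N(C)[C@@H](C)C1)N(C(=O)Nc1cccc(Cl)c1Cl)CC2`: 0.1 in an assay on isolated protein with 5-hydroxytryptamine receptor 1B (Homo sapiens) as the target; a higher number here means a larger maximal response, a lower number a smaller maximal response
Compound 2, `COc1cc2c(cc1N1C[C@@H](C)N(C)[C@@H](C)C1)N(C(=O)Nc1cccc(Cl)c1F)CC2`: 0.1
Compound 3, `COc1cc2c(cc1N1C[C@@H](C)N(C)[C@@H](C)C1)N(C(=O)Nc1cccc(C(F)(F)F)c1F)CC2`: 0

Compound 3 has the lowest of the three numbers in this assay, but only narrowly: a number 0.10 lower from compound 1 to compound 3 (within the scatter), and a number 0.10 lower from compound 2 to compound 3 (within the scatter), so it sits level with both. Compound 4, `COc1cc2c(cc1N1C[C@@H](C)N(C)[C@@H](C)C1)N(C(=O)Nc1cccc(C(F)(F)F)c1Cl)CC2`, is the next step from compound 3: chloro in place of fluoro on an aromatic carbon. Among the compounds with values here, one measured step bears on this exchange directly, taken the other way round: no change at the digits printed from compound 1 to compound 2 (within the scatter). Within the data shown here, no step among the three measured compounds moves this assay beyond the scatter, and the halogen swap in particular left it flat, so no shift beyond the scatter is expected here either: a number 0.050 higher from compound 3 to compound 4 (within the scatter). Compound 4 is therefore estimated at 0.05, with a range from 0 to 0.15.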

Compound 4, intrinsic activity: the largest response reached, as a fraction of the reference agonist's: 0
Compound 4: middle estimate off by 0.050, on the high side; measured number inside the range.
By their numbers in this assay, from the lowest: compounds 3, 4, 1 and 2 (each within the scatter of the next).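

At this position, ortho to a trifluoromethyl group, chloro in place of fluoro gives no change at the digits printed from compound 3 to compound 4 (within the scatter) in this assay, so the halogen exchange now reads the same on two cores: the same change on two cores in this assay, no change at the digits printed (within the scatter) from compound 1 to compound 2 and no change at the digits printed (within the scatter) from compound 4 to compound 3, 0 apart, within the scatter of two such steps

Trifluoromethyl in place of chloro also reads the same with either halogen present, with a number 0.10 lower from compound 1 to compound 4 (within the scatter) matching the earlier step: the same change on two cores in this assay, a number 0.10 lower (within the scatter) from compound 2 to compound 3 and a number 0.10 lower (within the scatter) from compound 1 to compound 4, 0 apart, within the scatter of two such steps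

The step that changes both groups, a number 0.10 lower from compound 2 to compound 4 (within the scatter), also stays within the scatter, so all four compounds remain level.

On these data alone, whether a methoxy group or an amine at this position would move the maximal response beyond the scatter stays open.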